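A Nitro Group Added to the Phenyl Terminus

A few compounds are considered here, and "the series" means these few. Any claim that something is new, unique, unknown or untested is made for them only; others in the source may bear on it.

In a functional assay on A549 cells (Homo sapiens) for inhibition, read by MTT assay, with a stated time of 72 h (on this read-out higher numbers stand for weaker inhibition and lower numbers for stronger inhibition), compound 1 `COc1ccc(/C=C/C=N/N2C(=S)NC3C2N(C)C(=O)N3C)cc1` gives > 100000 nM, which is a limit of the assay and not a number. Compound 2 `CN1C(=O)N(c2ccccc2)C2NC(=S)N(/N=C/C=C/c3ccccc3)C21` gives > 100000 nM in this assay, again a limit. Compound 3 `CCN1C(=O)N(CC)C2C1NC(=S)N2/N=C/C=C/c1ccccc1` gives 6530 nM in this assay, and it stands as the only number shown, since the other two values rest at the limit of > 100000 nM in this assay, at which 2 of the 3 values shown sit. Compound 4 `CCN1C(=O)N(CC)C2C1NC(=S)N2/N=C/C=C/c1ccccc1[N+](=O)[O-]` differs from compound 3 by a single change: nitro in place of hydrogen on an aromatic carbon. Within the data shown here, no step between measured compounds is available to guide the direction, so the step of a 1.1-fold higher number from compound 3 to compound 4 (0.03 log units; within the scatter) is expected to stay within the usual scatter. Compound 4 is therefore estimated at 7000 nM, within a range of 2000 nM to 30000 nM.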

Compound 4, half-maximal inhibitory concentration: > 100000 nM
Compound 4 was reported as a limit; the forecaster's own chance of this, stated with the estimate: 20%; at least 14-fold (1.15 log units) between middle value and limit.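

Nitro on this aromatic carbon, ortho to a large group, gives an at least 15-fold higher number from compound 3 to compound 4 (1.18 log units; beyond the scatter) in this assay and so shows that the phenyl terminus of compound 3 does not accept every change without consequence. The size of this step is only a lower bound, since compound 4 rests at a limit of the assay and not at a number: (the limit of > 100000 nM in this assay, at which 3 of the 4 values shown sit).

From the compounds shown here alone, whether the step belongs to nitro itself or to this position stays open. An amine or a fluorine on the same carbon, or nitro on another carbon of the ring, would separate the two.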